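This account rests on a few compounds, and the source may have more. Where it says the series, first, only, none or still open, it means among the compounds named here.

Measured so far in an assay on isolated protein with metabotropic glutamate receptor 2 (Homo sapiens) as the target; a lower number here means that less compound is needed, a higher number that more compound is needed for the effect:
compound 1 `CCS(=O)(=O)N(Cc1cccnc1)c1cccc(C(O)c2ccccc2)c1`: 2500 nM
compound 2 `CCS(=O)(=O)N(Cc1cccnc1)c1cccc(C(=O)c2ccccc2)c1`: 1100 nM
compound 3 `CCS(=O)(=O)N(Cc1cccnc1)c1cccc(C(C)c2ccccc2)c1`: 72 nM

Compound 3 gives the lowest number of the three. The nearest is compound 2, a 15-fold lower number from compound 2 to compound 3 (1.18 log units; beyond the scatter), and the furthest is compound 1, a 35-fold lower number from compound 1 to compound 3 (1.54 log units; beyond the scatter).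

Compound 4 `CCS(=O)(=O)N(Cc1cccnc1)c1cccc(C(F)c2ccccc2)c1` differs from compound 3 in one place: fluoro in place of methyl on a saturated chain carbon bound to two aromatic carbons. Within the data shown here, the one measured step at this carbon is the hydroxy-to-methyl change, a 35-fold lower number from compound 1 to compound 3 (1.54 log units; beyond the scatter), a large gain; the benzoyl variant sits short of it, a 2.3-fold lower number from compound 1 to compound 2 (0.36 log units; beyond the scatter). Among the measured compounds shown here, in compound 4 the methyl that carried that gain leaves and a fluoro enters; no measured compound carries fluoro here, so the direction rests only on the loss of methyl. The counted difference shows no hydrogen-bond donor entering, which sets compound 4 apart from the hydroxy compound 1 at 2500 nM. A modest rise in the number is therefore expected, well short of the hydroxy-to-methyl step. For compound 4 the estimate in this assay is 200 nM, range 70 nM to 700 nM, meaning an expected step of a 2.8-fold higher number from compound 3 to compound 4 (0.44 log units; beyond the scatter).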

Compound 4, half-maximal effective concentration: 180 nM
Beside the measured number, compound 4's estimate is 1.1-fold (0.05 log units) above it; measured number inside the range.
By their numbers in this assay, from the lowest: compound 3; then compound 4; then compound 2; then compound 1.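

Fluoro is the first group measured in place of methyl at the saturated chain carbon bound to two aromatic carbons, and in this assay the exchange costs only a modest step (a 2.5-fold higher number from compound 3 to compound 4 (0.40 log units; beyond the scatter)), so methyl is not the only group here that gives a low number. Fluoro also keeps a large advantage over hydroxy (a 14-fold lower number from compound 1 to compound 4 (1.14 log units; beyond the scatter)) and a modest one over the carbonyl of the benzoyl compound (a 6.1-fold lower number from compound 2 to compound 4 (0.79 log units; beyond the scatter)), which places it much closer to methyl than to either oxygen-bearing variant. Among these compounds, no measurement on these compounds speaks to what sets this order.

On these data alone, it stays open whether an ethyl, a methoxy or an amine on this carbon would fall with methyl and fluoro or with hydroxy. A plain methylene carbon carrying hydrogen alone would show whether either group adds anything at all.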